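The source may hold more compounds than are shown below. What is called first, only, known or untested is meant among the compounds shown, and "the series" means these compounds.

In a functional assay on KBVIN cells (Homo sapiens) for antiproliferative activity, read by sulforhodamine B assay, with a stated time of 3 days (on this read-out lower numbers stand for stronger inhibition of growth and higher numbers for weaker inhibition of growth), three amides built on one shared core have been measured. Compound 1 `O=C(Nc1ccc(C(F)(F)F)cc1)c1cccc(Nc2ncc(F)c(Nc3ccc(F)cc3)n2)c1` is reported only as a limit, > 10000 nM. Compound 2 `O=C(Nc1cc(Cl)cc(Cl)c1)c1cccc(Nc2ncc(F)c(Nc3ccc(F)cc3)n2)c1` gives 20700 nM. Compound 3 `Cn1ccnc1NC(=O)c1cccc(Nc2ncc(F)c(Nc3ccc(F)cc3)n2)c1` gives 13100 nM, which places it level with compound 2 once the scatter is taken into account. Within the data shown here, neither a step that the limit leaves unreadable from compound 1 to compound 2 nor a step that the limit leaves unreadable from compound 1 to compound 3 gives a usable size, so only one measured step can be read.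

Compound 4 `O=C(NCCO)c1cccc(Nc2ncc(F)c(Nc3ccc(F)cc3)n2)c1` carries 2-hydroxyethyl in place of 1-methyl-1H-imidazol-2-yl on an amide-type nitrogen. Among the measured compounds shown here, the entering group has no ring, and no measured compound tests a group without one at this place, so the comparison is an imperfect guide. For the measured compounds named here, the one readable step at this nitrogen is a 1.6-fold lower number from compound 2 to compound 3 (0.20 log units; within the scatter), and it exchanges one ring-bearing group for another. On the strength of that step, no change beyond the scatter is expected in this assay, though the uncertainty is wide. The estimate amounts to an expected 1.1-fold higher number from compound 3 to compound 4 (0.06 log units; within the scatter). For compound 4 the estimated value is 15000 nM, with an expected range from 6000 nM to 40000 nM.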

Compound 4, concentration for 50% growth inhibition: 21400 nM
The estimate for compound 4 lay 1.4-fold (0.15 log units) below the measured number; measured number inside the range.
By their numbers in this assay, from the lowest: compounds 3, 2 and 4 (each within the scatter of the next).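

In this assay, among these compounds, compound 4 puts a group without a ring on the amide-type nitrogen, which no earlier compound had done, and the numbers do not separate it from the ring-bearing groups: a 1.6-fold higher number from compound 3 to compound 4 (0.21 log units; within the scatter), and a 1.0-fold higher number from compound 2 to compound 4 (0.01 log units; within the scatter). Across compounds 2, 3 and 4, then, neither the presence of a ring on this nitrogen nor the change from 6 heavy atoms in 1-methyl-1H-imidazol-2-yl to 3 in 2-hydroxyethyl moves the number beyond the scatter, and the hydrogen-bond donor that 2-hydroxyethyl brings does not do so either. The step from compound 1 to compound 4 cannot be read, as compound 1 is reported only as a limit: the limit of > 10000 nM in this assay, at which 1 of the 4 values shown sits.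

The compounds shown leave open whether a primary amine or a carboxylic acid at the end of the chain, or a longer chain such as 3-hydroxypropyl, would give a number beyond the scatter at this nitrogen. They also leave open whether any change elsewhere on the shared core, such as replacing the 4-fluorophenyl group with an unsubstituted phenyl, would move the number in this assay, since every compound here differs only on this nitrogen.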